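Anilide series: cytotoxicity notes ahead of compound 4

This account rests on a few compounds, and the source may have more. Where it says the series, first, only, none or still open, it means among the compounds named here.

Measured so far:
compound 1, `O=C(CSc1snnc1-c1ccccc1)Nc1ccccc1F`, in an ADME assay on MT4 cells (Homo sapiens) for cytotoxicity; a higher number here means that more compound is tolerated, a lower number that less compound is tolerated: > 361000 nM, a limit rather than a number.
compound 2, `O=C(CSc1snnc1-c1ccc(Cl)cc1Cl)Nc1ccccc1F`, in this assay: 19500 nM.
compound 3, `O=C(CSc1snnc1-c1ccc(F)cc1F)Nc1ccccc1F`, in this assay: 148000 nM.

Compound 2 gives the lowest of the two numbers in this assay; the nearest measured neighbour is a 7.6-fold higher number from compound 2 to compound 3 (0.88 log units; beyond the scatter). The other two steps both start at the limit of compound 1 (the limit of > 361000 nM in this assay, at which 1 of the 3 values shown sits): an at least 18-fold lower number from compound 1 to compound 2 (1.26 log units; beyond the scatter) and an at least 2.4-fold lower number from compound 1 to compound 3 (0.38 log units; beyond the scatter). Both concern the aryl group on the shared core and leave the anilide ring untouched.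

Compound 4, `O=C(CSc1snnc1-c1ccc(Cl)cc1Cl)Nc1ccccc1[N+](=O)[O-]`, differs from compound 2 only on the anilide ring: nitro in place of fluoro on an aromatic carbon. Among the compounds with values here, no measured step alters this ring, so no step bears directly on the change; the three measured steps give no guidance on it. In the absence of such evidence the expected step of a 1.3-fold lower number from compound 2 to compound 4 (0.11 log units; within the scatter) is none beyond the scatter. Compound 4 is therefore estimated at 15000 nM in this assay, in the range 5000 nM to 60000 nM.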

Compound 4, half-maximal cytotoxic concentration: > 283000 nM
Compound 4: no number, only a limit; the forecaster's own chance of this, stated with the estimate: 5%; middle value at least 18-fold (1.27 log units) from the limit.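

In this assay, the anilide ring proves to be a second place where the read-out moves: nitro in place of fluoro, ortho to a large group, gives an at least 14-fold higher number from compound 2 to compound 4 (1.16 log units; beyond the scatter). Compound 4 gives a limit and not a number: the limit of > 283000 nM in this assay, at which 1 of the 4 values shown sits. All earlier steps changed only the aryl group on the shared core, so the low number of compound 2 had been read against that group alone, whereas compound 4 keeps the 2,4-dichlorophenyl group and no longer shows a low number.

On these data alone, the true value of compound 4 remains unknown, so the full size of this step stays open. Also open, as far as these compounds go, are whether an amine or a carboxylic acid on this carbon would give a similar result, and whether 2-nitrophenyl would do so alongside the 2,4-difluorophenyl or phenyl group.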